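From cyclopropyl to 1,1-dimethylpropyl on the shared core

The compounds below may be only part of what the source reports. "The series", "measured", "known", "first", "only" and "open" are said of these compounds alone.

In a functional assay on NCI-H460 cells (Homo sapiens) for cytotoxicity, read by MTT assay, with a stated time of 48 h (on this read-out lower numbers stand for stronger inhibition and higher numbers for weaker inhibition), compound 1 `C=C1C(=O)O[C@H]2CC3=C[C@H](C/C(C)=C/[C@@H](OC(=O)/C=C/c4cccc(OC)c4)[C@H]12)OC3=O` gives > 10000 nM, a limit of the assay and not a number. Among the compounds with values here, compound 2 `C=C1C(=O)O[C@H]2CC3=C[C@H](C/C(C)=C/[C@@H](OC(=O)C4CC4)[C@H]12)OC3=O` gives 3000 nM, the only true number so far. Compound 3 `C=C1C(=O)O[C@H]2CC3=C[C@H](C/C(C)=C/[C@@H](OC(=O)C(C)(C)CC)[C@H]12)OC3=O` carries 1,1-dimethylpropyl in place of cyclopropyl on a carbonyl carbon. Within the data shown here, the sole measured guide, an at least 3.3-fold lower number from compound 1 to compound 2 (0.52 log units; beyond the scatter), involves a different group and so bears only loosely on this change. The expected step is a 1.3-fold higher number from compound 2 to compound 3 (0.12 log units; within the scatter), which would stay within the scatter. Compound 3 is estimated at 4000 nM, with an expected range from 1200 nM to 10000 nM.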

Compound 3, half-maximal inhibitory concentration: 6100 nM
Compound 3: middle estimate off by 1.5-fold (0.18 log units), on the low side, within the range that was stated.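

Putting 1,1-dimethylpropyl in place of cyclopropyl on the carbonyl carbon gives a 2.0-fold higher number from compound 2 to compound 3 (0.31 log units; beyond the scatter), so this position responds even when one carbon-only group replaces another, with no hydrogen-bond donors or acceptors on either side. Putting 1,1-dimethylpropyl in place of 2-(3-methoxyphenyl)ethenyl gives an at least 1.6-fold lower number from compound 1 to compound 3 (0.21 log units; that floor lies within the scatter), which does not firmly separate those two compounds. The value of compound 1 is a limit of the assay and not a number: the limit of > 10000 nM in this assay, at which 1 of the 3 values shown sits. As far as these compounds go, whether an amine, a carboxylic acid or a longer straight chain at this position would give a lower number than compound 2 stays open.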